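Adding Bromo to a Core That Shows No Inhibition

The source may report more compounds than this note shows. Statements on the series, on what has been measured and on what is new or still open speak of the compounds shown alone.

Compound 1 `O=C(NC1(C(=O)O)CCCCC1)c1cc(F)cc2cc(-c3ccc(Cl)cc3)oc12` and compound 2 `O=C(NC1(C(=O)O)CCCCC1)c1cccc2cc(-c3ccc(Cl)cc3)oc12` were tested in an assay on isolated protein for inhibition of endoplasmic reticulum aminopeptidase 2 (Homo sapiens); on this read-out lower numbers stand for stronger inhibition and higher numbers for weaker inhibition. In this assay compound 1 reaches only the limit > 30000 nM. In this assay compound 2 likewise returns only the limit > 30000 nM. Within the data shown here, the one measured step, a step that the two limits leave unreadable from compound 1 to compound 2, cannot be read because both values sit at the limit of > 30000 nM in this assay, at which 2 of the 2 values shown sit. Compound 3 `O=C(NC1(C(=O)O)CCCCC1)c1cccc2c(Br)c(-c3ccc(Cl)cc3)oc12` differs from compound 2 by bromo in place of hydrogen on an aromatic carbon. Among the measured compounds shown here, no measured step touches this position of the core, and the only step known, hydrogen in place of fluoro on the other ring, did not move compound 2 off the limit. Compound 3 is therefore expected to stay at the limit as well, with an estimated value of 30000 nM and a range from 10000 nM to 100000 nM. This expectation means a step of a number no higher from compound 2 to compound 3 (the limit leaves the size open) of no readable size beyond the scatter.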

Compound 3, half-maximal inhibitory concentration: > 30000 nM
Compound 3 gave a limit, no number; the forecaster's own chance of this, stated with the estimate: 80%; the middle value sits exactly at the limit.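

Compound 2 and compound 3 both stop at a limit in this assay, so the step between them cannot be read: the limit of > 30000 nM in this assay, at which 3 of the 3 values shown sit. The compounds shown leave open how strongly each inhibits, and whether bromo in place of hydrogen changes inhibition at all.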